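The source may hold more compounds than are shown below. What is called first, only, known or untested is meant among the compounds shown, and "the series" means these compounds.

The measured compounds:
Compound 1, `COc1cc(C2(C(=O)NCc3ccc(C(C)(C)C)cc3)CC2)ccc1NS(C)(=O)=O`: 2250 nM
Compound 2, `CC(C(=O)NCc1ccc(Cl)c(Cl)c1)c1ccc(NS(C)(=O)=O)c(F)c1`: 115 nM
Compound 3, `CC(C(=O)NCc1ccc(C(F)(F)F)cc1)c1ccc(NS(C)(=O)=O)c(F)c1`: 274 nM

All three were tested in a functional assay on CHO cells for antagonist activity at transient receptor potential cation channel subfamily V member 1 (Rattus norvegicus); on this read-out higher numbers stand for weaker inhibition and lower numbers for stronger inhibition. Compound 3 stands second highest of the three numbers: compound 2 gives the nearest number, lower and beyond the scatter, while compound 1 gives a much higher number, also beyond the scatter. Compound 1 has a different core, so its number says little about the step at hand.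

Compound 4, `CC(C(=O)NCc1ccc(C2C=CCC2)cc1)c1ccc(NS(C)(=O)=O)c(F)c1`, shares the core of compound 3 and differs from it in one place: cyclopent-2-en-1-yl in place of trifluoromethyl on an aromatic carbon. Going by the values given here, no measured pair shows this change, so the size of the step can only be judged from the numbers in hand. Compounds 2 and 3 show that the group at this place can move the number by more than the scatter, yet both stay in the same region. For compound 4 the expected step of a 1.4-fold lower number from compound 3 to compound 4 (0.14 log units; within the scatter) is small, not beyond the scatter, if anything toward a lower number. Compound 4 is accordingly estimated at 200 nM, with a range from 60 nM to 700 nM in this assay.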

Compound 4, inhibition constant: 15 nM
The estimate for compound 4 lay 13-fold (1.12 log units) above the measured number, outside the stated range (below it).
By their numbers in this assay, from the lowest: compound 4; then compound 2; then compound 3; then compound 1.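

In this assay, putting cyclopent-2-en-1-yl in place of trifluoromethyl on the aromatic carbon gives an 18-fold lower number from compound 3 to compound 4 (1.26 log units; beyond the scatter) and so shows that a change at this one place on the shared core can strengthen inhibition by a large step. Going by these compounds alone, until now, no pair of measured compounds differed in only one place, so the size of such a step could not be read directly. No measurement at hand ties this step to any property of the two groups, so the data give only its size and direction.

Going by these compounds, it remains open whether the stronger inhibition depends on the five-membered ring or on its double bond, and the saturated cyclopentyl group at the same place would separate these two features. The compounds shown also leave open how a cyclic amine such as pyrrolidin-1-yl or a longer chain such as n-pentyl would behave at this place, and whether the step would carry over to the core of compound 1.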